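The source may report more compounds than this note shows. Statements on the series, on what has been measured and on what is new or still open speak of the compounds shown alone.

Measured compounds:
compound 1 `COc1cccc(/C=C/C[C@@H]2C[C@@H]([C@@H](O)c3ccc(OC)c(OC)c3)CO[C@H]2c2ccc(OC)c(OC)c2)c1`, 16400 nM
compound 2 `COc1ccc([C@H]2OC[C@H]([C@@H](O)c3ccc(OC)c(OC)c3)C[C@@H]2C/C=C/c2ccccc2)cc1OC`, 14800 nM

Both values come from a functional assay on HeLa cells (Homo sapiens) for cytotoxicity, read by WST assay, with a stated time of 48 h; on this read-out higher numbers stand for weaker inhibition and lower numbers for stronger inhibition. In this assay compound 1 gives 16400 nM and compound 2 gives 14800 nM. Compound 2 shows the lower number of the two, but the gap to compound 1 is within the scatter, so the two compounds are treated as equal on these numbers. Within the data shown here, compound 1 differs from compound 2 in more than one place, so no single step is drawn between them.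

The next compound, compound 3 `COc1ccc(/C=C/C[C@H]2C[C@@H]([C@@H](O)c3ccc(OC)c(OC)c3)CO[C@@H]2c2ccc(OC)c(OC)c2)cc1`, is unmeasured. It differs from compound 2 in one place:
methoxy in place of hydrogen on an aromatic carbon
Among the measured compounds shown here, no step between measured compounds covers this change, so there is no precedent for what it does here. The expectation is a step from compound 2 to compound 3 of no more than the usual scatter, in either direction, written as a 1.1-fold lower number from compound 2 to compound 3 (0.02 log units; within the scatter). Compound 3 is therefore estimated at 14000 nM in this assay, with a range from 6000 nM to 30000 nM, which keeps it near compound 2 and compound 1 in this assay.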

Compound 3, half-maximal inhibitory concentration: 12200 nM
Beside the measured number, compound 3's estimate is 1.1-fold (0.06 log units) above it, within the range that was stated.
By their numbers in this assay, from the lowest: compounds 3, 2 and 1 (each within the scatter of the next).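

Among these compounds, the change from 3-phenylprop-2-en-1-yl to 3-(4-methoxyphenyl)prop-2-en-1-yl provides the first single-place step, and in this assay it reads a 1.2-fold lower number from compound 2 to compound 3 (0.08 log units; within the scatter) on the shared core. This aromatic carbon, para to a large group, therefore takes methoxy in place of hydrogen with no step beyond the scatter, and compound 2 and compound 3 count as equal on these numbers. This single step covers one group at one position only, and no measurement shown here offers an explanation for the result.

The compounds shown carry only hydrogen or methoxy on this aromatic ring, so it remains open whether an amine, a carboxylic acid or a hydroxyl group on this carbon would give a step beyond the scatter. Going by these compounds, it also remains open whether a longer chain in place of the prop-2-en-1-yl link would move the number away from that of compound 3 at 12200 nM in this assay or leave it within the scatter.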